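The source may report more compounds than this note shows. Statements on the series, on what has been measured and on what is new or still open speak of the compounds shown alone.

Compound 1 `Nc1ccc2cccc(OC3CCC3)c2n1`, compound 2 `CC1CCCC(Oc2cccc3ccc(N)nc23)C1` and compound 3 `Nc1ccc2cccc(OCCC3CCCCC3)c2n1` share one core and differ only in the ether substituent on its aromatic ring. In an assay on cells with melanin-concentrating hormone receptor 1 (Homo sapiens) as the target, read by radioligand binding (on this read-out lower numbers stand for stronger inhibition and higher numbers for weaker inhibition), compound 1 gives > 2000 nM, which is a limit of the assay rather than a number. In this assay compound 2 gives 640 nM and compound 3 gives 808 nM; these two values lie within the scatter of each other, so compound 3 is not separated from compound 2, and it carries the higher of the two numbers shown. Compound 4 `COC(C)(C)CCOc1cccc2ccc(N)nc12` has not been measured in this assay. It differs from compound 3 by the change (1-methoxy-1-methylethyl in place of cyclohexyl on a saturated chain carbon, two bonds along the chain from an oxygen on an aromatic ring), a cyclohexyl giving way to 1-methoxy-1-methylethyl on a saturated chain carbon, two bonds along the chain from an oxygen on an aromatic ring. Within the data shown here, no step between measured compounds covers such a change, so the direction rests on the structural change alone. The step of a 1.9-fold higher number from compound 3 to compound 4 (0.27 log units; within the scatter) is expected to be a modest weakening, possibly within the scatter. Compound 4 is therefore estimated at 1500 nM, with a plausible range from 500 nM to 4000 nM in this assay.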

Compound 4, half-maximal inhibitory concentration: 132 nM
Compound 4: the middle estimate sits 11-fold (1.06 log units) above what was measured; measured number below the stated range.
By their numbers in this assay, from the lowest: compound 4; then compounds 2 and 3 (each within the scatter of the next). At a limit, above all of these: compound 1.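

In this assay, 1-methoxy-1-methylethyl in place of cyclohexyl on a saturated chain carbon, two bonds along the chain from an oxygen on an aromatic ring, gives a 6.1-fold lower number from compound 3 to compound 4 (0.79 log units; beyond the scatter) and so separates two compounds at this place. It shows that the cyclohexyl ring is not required here: a group with no ring and with a hydrogen-bond acceptor carries the lower number. Nothing measured here explains the step, and this single pair cannot tell whether the gain follows the oxygen that enters or the ring that leaves.

As far as these compounds go, it remains open whether a plain methoxy on the same chain, without the branching, would give a similar number. From the compounds shown here alone, it is equally open how an amine, a carboxylic acid or a longer chain would compare with 1-methoxy-1-methylethyl at this place.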